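This account rests on a few compounds, and the source may have more. Where it says the series, first, only, none or still open, it means among the compounds named here.

Compound 1 `C[C@H](NC(=O)C(=O)Nc1ccccc1)C(=O)N[C@@H](CC(=O)O)C(=O)COc1c(F)c(F)cc(F)c1F` and compound 2 `C[C@H](NC(=O)C(=O)Nc1ccccc1-c1ccccc1)C(=O)N[C@@H](CC(=O)O)C(=O)COC(=O)c1c(F)c(F)cc(F)c1F` were both tested in a functional assay on THP-1 cells (Homo sapiens) for inhibition; a higher number here means a weaker inhibitor, a lower number a stronger inhibitor. Compound 1 gives 140 nM, the lower of the two numbers in hand. Compound 2 gives 500 nM in this assay, a higher number that lies beyond the scatter; since compound 2 differs from compound 1 in more than one place, the two values show only that the larger molecule is the weaker inhibitor here, not which change is responsible.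

Compound 3 `C[C@H](NC(=O)C(=O)Nc1ccccc1Cc1ccccc1)C(=O)N[C@@H](CC(=O)O)C(=O)COc1c(F)c(F)cc(F)c1F` has not been measured. It differs from compound 1 by benzyl in place of hydrogen on an aromatic carbon. Among the measured compounds shown here, no measured pair isolates this change, so the expected step rests on the general picture: compound 1 with 140 nM is the stronger of the two known compounds, and the only added bulk seen so far, in compound 2 with 500 nM, went with a weaker result. A modest move toward a higher number is therefore expected, of the size a 1.8-fold higher number from compound 1 to compound 3 (0.25 log units; within the scatter), though an outcome within the scatter would not surprise. Compound 3 is expected to give about 250 nM in this assay, between 100 nM and 650 nM.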

Compound 3, half-maximal inhibitory concentration: 540 nM
The estimate for compound 3 lay 2.2-fold (0.33 log units) below the measured number; measured number inside the range.
By their numbers in this assay, from the lowest: compound 1; then compounds 2 and 3 (each within the scatter of the next).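

In this assay, putting benzyl in place of hydrogen on an aromatic carbon, ortho to a large group, gives a 3.9-fold higher number from compound 1 to compound 3 (0.59 log units; beyond the scatter), a step beyond the scatter of repeated measurements. This is the first comparison here in which only one place in the molecule changes, so the loss of inhibition can be tied to this single addition rather than to several differences at once, and this aromatic carbon is shown not to accept benzyl without a cost in this assay. No measurement available here explains why the added benzyl has this effect, so the result records what happens but not its cause.

From the compounds shown here alone, it remains open whether a smaller group at the same carbon, such as methyl, fluorine or methoxy, would stay closer to compound 1, or whether a group carrying an amine or a carboxylic acid would do better or worse. Going by these compounds, it is also open whether benzyl would cost as much on another carbon of that aromatic ring, or with a different group at the other end of the molecule.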